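Moving the Methoxy Group from Compound 3 to Compound 4

The compounds below may be only part of what the source reports. "The series", "measured", "known", "first", "only" and "open" are said of these compounds alone.

Values measured in an ADME assay on THP-1 cells (Homo sapiens) for cytotoxicity, read by flow cytometry and propidium iodide staining, with a stated time of 72 h; on this read-out lower numbers stand for stronger inhibition and higher numbers for weaker inhibition:
Compound 1 `COc1ccc(-c2oc3ccc(NC(C)=O)cc3c(=O)c2O)cc1`: 9000 nM
Compound 2 `COc1c(-c2ccccc2)oc2ccc(NC(C)=O)cc2c1=O`: > 125000 nM
Compound 3 `COc1ccccc1-c1oc2ccc(NC(C)=O)cc2c(=O)c1OC`: 108000 nM

Compound 2 has a value that is a limit of the assay and not a number. Among the two actual numbers, compound 3 has the higher, 108000 nM. Compound 1 gives 9000 nM, and the gap between the two lies beyond the scatter.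

Compound 4 `COc1ccc(-c2oc3ccc(NC(C)=O)cc3c(=O)c2OC)cc1` carries 4-methoxyphenyl in place of 2-methoxyphenyl on an aromatic carbon next to the ring oxygen (4-methoxyphenyl in place of 2-methoxyphenyl on an aromatic carbon). For the measured compounds named here, no measured step makes this exact change. The nearest is an at least 1.1-fold lower number from compound 2 to compound 3 (0.06 log units; that floor lies within the scatter), and it rests on (the limit of > 125000 nM in this assay, at which 1 of the 3 values shown sits). It therefore gives little guidance on size. Going by the values given here, compound 1, at 9000 nM, is the only measured compound with 4-methoxyphenyl, which points weakly towards a lower number in this assay. Only a small change is expected, probably not beyond the scatter. The expected step is a 1.5-fold lower number from compound 3 to compound 4 (0.19 log units; within the scatter). For compound 4 the estimated value is 70000 nM, with an expected range from 30000 nM to 125000 nM.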

Compound 4, half-maximal inhibitory concentration: > 50000 nM
Compound 4: no number, only a limit (the forecaster's own chance of this, stated with the estimate: 20%); the middle value is on the limit's open side.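

For compound 4, this assay gives no number, only a limit: the limit of > 50000 nM in this assay, at which 1 of the 4 values shown sits.

The steps to compound 4 from compound 3 and from compound 2 cannot be read, so 4-methoxyphenyl in place of 2-methoxyphenyl on this aromatic carbon still has no measured size. For the compounds shown here, one step can be read, and no earlier pair showed this change: with 4-methoxyphenyl kept, methyl in place of hydrogen on the oxygen on the aromatic ring gives an at least 5.5-fold higher number from compound 1 to compound 4 (0.74 log units; beyond the scatter).

The compounds shown leave open how far 2-methoxyphenyl and 4-methoxyphenyl differ at this carbon when everything else is kept the same. They also leave open how this assay would respond to a longer chain such as ethyl on that oxygen, or to an amine in place of the methoxy group of 4-methoxyphenyl.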